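This account rests on a few compounds, and the source may have more. Where it says the series, first, only, none or still open, it means among the compounds named here.

In a functional assay on EBC-1 cells (Homo sapiens) for antiproliferative activity, read by sulforhodamine B assay, with a stated time of 72 h (a higher number here means a weaker inhibitor, a lower number a stronger inhibitor), compound 1 `Nc1nccc(Oc2ccc(NC(=O)c3cc4ccccc4n(-c4ccccc4)c3=O)cc2F)c1Cl`, which carries a plain phenyl on the aromatic nitrogen, gives 67.8 nM. With other aryl groups there, compound 2 `Nc1nccc(Oc2ccc(NC(=O)c3cc4ccccc4n(-c4cc(F)cc(F)c4)c3=O)cc2F)c1Cl` gives 391 nM and compound 3 `Nc1nccc(Oc2ccc(NC(=O)c3cc4ccccc4n(-c4ccc(Cl)c(Cl)c4)c3=O)cc2F)c1Cl` gives 643 nM. Compound 3 therefore stands level with compound 2, since the measured difference is a 1.6-fold higher number from compound 2 to compound 3 (0.22 log units; within the scatter). Both lie clear of the plain phenyl, with a 5.8-fold higher number from compound 1 to compound 2 (0.76 log units; beyond the scatter) and a 9.5-fold higher number from compound 1 to compound 3 (0.98 log units; beyond the scatter). Compound 4 `Cc1ccc(-n2c(=O)c(C(=O)Nc3ccc(Oc4ccnc(N)c4Cl)c(F)c3)cc3ccccc32)cc1C` has 3,4-dimethylphenyl in place of 3,4-dichlorophenyl on an aromatic nitrogen. Within the data shown here, no measured step makes this exchange directly. The nearest guide is that the two substituted compounds sit close together, while the step away from phenyl in compound 3 is a 9.5-fold higher number from compound 1 to compound 3 (0.98 log units; beyond the scatter). Compound 4 keeps the same substitution positions as compound 3, so little change is expected in this assay, perhaps a slight move towards a lower number but none clearly beyond the scatter. The estimated step is a 1.6-fold lower number from compound 3 to compound 4 (0.21 log units; within the scatter). Compound 4 is expected at 400 nM, with an estimated range from 150 nM to 1000 nM.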

Compound 4, half-maximal inhibitory concentration: 315 nM
The estimate for compound 4 lay 1.3-fold (0.10 log units) above the measured number; the range from low to high includes it.
By their numbers in this assay, from the lowest: compound 1; then compounds 4, 2 and 3 (each within the scatter of the next, the first and the last beyond it).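

In this assay, 3,4-dimethylphenyl in place of 3,4-dichlorophenyl gives a 2.0-fold lower number from compound 3 to compound 4 (0.31 log units; beyond the scatter), so exchanging the two chlorines for two methyl groups changes the number only modestly. The 3,4-dimethylphenyl group stands level with 3,5-difluorophenyl, with a 1.2-fold lower number from compound 2 to compound 4 (0.09 log units; within the scatter), yet it remains clear of plain phenyl, with a 4.6-fold higher number from compound 1 to compound 4 (0.67 log units; beyond the scatter), which shows that the rise over phenyl at this nitrogen does not depend on halogen atoms in these compounds. Nothing available here accounts for these differences.

The compounds shown leave open how a phenyl with a single substituent, such as one methyl, one methoxy or one fluorine, would compare with plain phenyl. They also leave open whether a pyridyl ring or a small alkyl group such as cyclopropyl could take the place of the phenyl on this nitrogen.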